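Swapping the Aryl on the Triazole Nitrogen

The source may hold more compounds than are shown below. What is called first, only, known or untested is meant among the compounds shown, and "the series" means these compounds.

Compound 1 `CC(C)n1ncc2c(C(=O)NCc3ccccc3)cccc21`: > 40000 nM
Compound 2 `Cc1ccc(-n2cc(CNC(=O)c3cccc4c3cnn4C(C)C)nn2)c(C)c1`: > 40000 nM

The two measured compounds share one core and differ in what hangs from the amide. In a functional assay on MGC-803 cells (Homo sapiens) for inhibition, read by MTT assay, with a stated time of 72 h (a higher number here means a weaker inhibitor, a lower number a stronger inhibitor), compound 1 gives > 40000 nM, which is a limit of the assay and not a number. Compound 2 gives > 40000 nM in this assay, again a limit rather than a measured number. Compound 2 thus stands at the limit of > 40000 nM in this assay, at which 2 of the 2 values shown sit, and on the numbers shown nothing separates it from compound 1.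

Compound 3 `CC(C)n1ncc2c(C(=O)NCc3cn(-c4ccc([N+](=O)[O-])cc4)nn3)cccc21` differs from compound 2 in one place: 4-nitrophenyl in place of 2,4-dimethylphenyl on an aromatic nitrogen. Within the data shown here, no step between measured compounds exists here, so the size of a step in this assay cannot be read from the data. The expectation is therefore a step of no more than the usual scatter, and most likely a reading that is once more only a limit. Compound 3 is expected to give about 45000 nM in this assay, somewhere between 15000 nM and 150000 nM, which would mean an estimated step that the limit leaves unreadable from compound 2 to compound 3.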

Compound 3, half-maximal inhibitory concentration: > 40000 nM
Compound 3: only a limit was reported (the forecaster's own chance of this, stated with the estimate: 80%); the middle value is on the limit's open side.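

Compound 2 and compound 3 each give only a limit of the assay and not a number, and no step can be read between them: the limit of > 40000 nM in this assay, at which 3 of the 3 values shown sit. The compounds shown leave open how 2,4-dimethylphenyl and 4-nitrophenyl on the aromatic nitrogen truly compare, and whether any compound on the shared core reaches a measurable value in this assay.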